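Adding a Methoxy Group to Compound 1: An Expectation

The source may hold more compounds than are shown below. What is called first, only, known or untested is meant among the compounds shown, and "the series" means these compounds.

Compound 1, `CC1=CC[C@H](C(C)(C)NC(=S)N/N=C/c2ccc(O)cc2)CC1`, gives > 100000 nM in a functional assay on 786-0 cells (Homo sapiens) for inhibition, read by sulforhodamine B assay, with a stated time of 48 h (on this read-out lower numbers stand for stronger inhibition of growth and higher numbers for weaker inhibition of growth), which is a limit of the assay rather than a number.
Compound 2, `CC1=CC[C@H](C(C)(C)NC(=S)N/N=C/c2ccccc2O)CC1`, gives 12100 nM in this assay.
Compound 3, `CC1=CC[C@H](C(C)(C)NC(=S)N/N=C/c2ccc(Cl)cc2)CC1`, gives > 100000 nM in this assay, again a limit.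

Compound 1 thus stands at the limit of > 100000 nM in this assay, at which 2 of the 3 values shown sit, so its own position is known only as a bound. Compound 4, `COc1cc(/C=N/NC(=S)NC(C)(C)[C@H]2CC=C(C)CC2)ccc1O`, differs from compound 1 by methoxy in place of hydrogen on an aromatic carbon, ortho to a hydroxy group. Going by the values given here, no measured step makes this change. The steps of an at least 8.2-fold lower number from compound 1 to compound 2 (0.91 log units; beyond the scatter) and an at least 8.2-fold higher number from compound 2 to compound 3 (0.91 log units; beyond the scatter) concern the hydroxy group itself, which compound 4 keeps, and the step that the two limits leave unreadable from compound 1 to compound 3 is unreadable. The expected step is therefore small, an at least 1.2-fold lower number from compound 1 to compound 4 (0.09 log units; that floor lies within the scatter), with a limit still likely. For compound 4 the estimate is 80000 nM, between 20000 nM and 300000 nM.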

Compound 4, concentration for total growth inhibition: 35400 nM
Estimate against measurement, compound 4: 2.3-fold (0.35 log units) above; measured number inside the range.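

Going by these compounds alone, until now, the only readable steps concerned the hydroxy group itself. This result shows that a methoxy group on an aromatic carbon, ortho to a hydroxy group, also strengthens growth inhibition while that hydroxy group stays in place, with an at least 2.8-fold lower number from compound 1 to compound 4 (0.45 log units; beyond the scatter). The full size of this step remains unknown because the value of compound 1 is a limit: the limit of > 100000 nM in this assay, at which 2 of the 4 values shown sit.

On these data alone, whether an amine, a carboxylic acid or a longer chain such as ethoxy at this position would give a lower or a higher number remains open. So does whether the methoxy group would lower the number without the hydroxy group.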